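The source may hold more compounds than are shown below. What is called first, only, known or untested is meant among the compounds shown, and "the series" means these compounds.

Compound 1, with the structure `COc1ccc(F)cc1CNCCCNc1ccnc2cc(Oc3ccc(F)cc3)ccc12`, carries a benzyl group on an amine nitrogen at one end of a saturated chain. In a physicochemical assay for acid dissociation, compound 1 gives 9.28. Compound 2, `COc1cccc(CNCCCNc2ccnc3cc(Oc4ccc(F)cc4)ccc23)c1O`, differs from it by 2-hydroxy-3-methoxyphenyl in place of 5-fluoro-2-methoxyphenyl on a saturated chain carbon bound to an amine nitrogen, and in this assay compound 2 gives 9.28. Compound 3, `COc1ccc(F)cc1CNCCCNc1ccnc2cc(-c3ccc(C(F)(F)F)cc3)ccc12`, differs from compound 1 in its core by 4-(trifluoromethyl)phenyl in place of 4-fluorophenoxy on an aromatic carbon; in this assay compound 3 gives 9.47, a step of a number 0.19 log units higher from compound 1 to compound 3 (within the scatter). Compound 4, `COc1cccc(CNCCCNc2ccnc3cc(-c4ccc(C(F)(F)F)cc4)ccc23)c1O`, is not yet measured. It differs from compound 3 by 2-hydroxy-3-methoxyphenyl in place of 5-fluoro-2-methoxyphenyl on a saturated chain carbon bound to an amine nitrogen, the same change at the same place as that from compound 1 to compound 2. Because that earlier change gave no change at the digits printed from compound 1 to compound 2 (within the scatter), the step from compound 3 to compound 4 is expected to be no change at the digits printed from compound 3 to compound 4 (within the scatter). Compound 4 is therefore estimated at 9.47, most likely between 9.2 and 9.75.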

Compound 4, acid dissociation constant: 9.47
Compound 4: middle estimate and measured number agree at the digits printed; the range from low to high includes it.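

In this assay the change to 2-hydroxy-3-methoxyphenyl gives no change at the digits printed from compound 3 to compound 4 (within the scatter) and, on the other core, no change at the digits printed from compound 1 to compound 2 (within the scatter) so for these two cores it carries over without a visible shift. Swapping 4-fluorophenoxy for 4-(trifluoromethyl)phenyl gives a number 0.19 log units higher from compound 2 to compound 4 (within the scatter) and likewise a number 0.19 log units higher from compound 1 to compound 3 (within the scatter) but all these steps lie within the scatter, and one pair of cores says nothing about any other core. Nothing measured here explains this result.

Still open, as far as these compounds go, is whether the match would hold with a longer chain joining the two amine nitrogens. Also open, from the compounds shown here alone, is what a carboxylic acid on the benzyl ring would do to this number.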